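Dichlorophenyl for dimethylphenyl on the ring amine nitrogen

The source may hold more compounds than are shown below. What is called first, only, known or untested is meant among the compounds shown, and "the series" means these compounds.

Measured so far:
compound 1 `Cc1cccc(N2CCN(CCCNc3nc(NCc4ccco4)c4ccccc4n3)CC2)c1C`: 770 nM
compound 2 `COc1ccc(Nc2nc(NCc3ccco3)c3cc(F)ccc3n2)cc1`: 6150 nM

In a functional assay on HCT-116 cells (Homo sapiens) for cytotoxicity, read by MTT assay, with a stated time of 2 days (on this read-out lower numbers stand for stronger inhibition and higher numbers for weaker inhibition), compound 1 gives 770 nM, the lowest of the two numbers in hand. Compound 2 gives 6150 nM, and the gap between the two is beyond the scatter. Among the measured compounds shown here, compound 2 differs from compound 1 in several places at once, so no single-point step between measured compounds is available; the two values show only that compound 1 stands lower.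

Compound 3 `Clc1cccc(N2CCN(CCCNc3nc(NCc4ccco4)c4ccccc4n3)CC2)c1Cl` has not yet been measured. It differs from compound 1 by 2,3-dichlorophenyl in place of 2,3-dimethylphenyl on an amine nitrogen in a ring. For the measured compounds named here, no measured step of this kind exists, so the expectation rests on the close match in size of the group that leaves and the group that enters: the step expected from compound 1 to compound 3 in this assay is a 1.1-fold lower number from compound 1 to compound 3 (0.04 log units; within the scatter), that is, none beyond the scatter. Compound 3 is estimated at 700 nM, with a range from 250 nM to 2000 nM.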

Compound 3, half-maximal inhibitory concentration: 3360 nM
Compound 3: middle estimate off by 4.8-fold (0.68 log units), on the low side; the whole stated range lies below it.
By their numbers in this assay, from the lowest: compound 1; then compounds 3 and 2 (each within the scatter of the next).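

Among the compounds shown here, replacing 2,3-dimethylphenyl with 2,3-dichlorophenyl on the amine nitrogen in a ring gives a 4.4-fold higher number from compound 1 to compound 3 (0.64 log units; beyond the scatter) in this assay and provides the first single-place reading. The two groups have the same heavy-atom count, the same six-membered aromatic ring of carbon only and the same donor and acceptor counts, yet the change is beyond the scatter, so this position distinguishes between them despite those shared counts. Nothing measured here accounts for the step.

The compounds shown leave open whether one ring substituent alone carries the difference, as an unsubstituted phenyl or a 3-methylphenyl on that nitrogen would test. Also open, on these data alone, is how a longer chain linking the six-membered non-aromatic ring to the shared core would affect the read-out.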